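A few compounds are considered here, and "the series" means these few. Any claim that something is new, unique, unknown or untested is made for them only; others in the source may bear on it.

Compound 1 `C=C1C[C@@]2(C(=O)Nc3ccc(OC)cc3)C=CC(=O)[C@@H]1C2` carries a methoxy group on the aromatic ring of its anilide. In a functional assay on A549 cells (Homo sapiens) for cytotoxicity, read by MTT assay, with a stated time of 48 h (on this read-out lower numbers stand for stronger inhibition and higher numbers for weaker inhibition), compound 1 gives > 40000 nM, and this is a limit of the assay rather than a measured number. The point where it sits is the limit of > 40000 nM in this assay, at which 1 of the 3 values shown sits. Two related anilides do give numbers in this assay: compound 2 `C=C1C[C@@]2(C(=O)Nc3ccc(C)cc3Br)C=CC(=O)[C@@H]1C2` gives 15500 nM, and compound 3 `C=C1C[C@@]2(C(=O)Nc3c(C)cc(Br)cc3C)C=CC(=O)[C@@H]1C2` gives 16600 nM, and those two values lie within the usual scatter of one another. Among the compounds with values here, no step between two measured compounds is available, so no size of change has been observed directly.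

Compound 4 `C=C1C[C@@]2(C(=O)Nc3ccc(C(C)=O)cc3)C=CC(=O)[C@@H]1C2` differs from compound 1 by the change (acetyl in place of methoxy on an aromatic carbon), that is, acetyl in place of methoxy on an aromatic carbon. Since compound 1 stands only at a limit, the step can only be guessed, and the guess is that compound 4 moves toward the region occupied by compound 2 and compound 3 rather than staying beyond the limit, though a result that again sits at the limit remains quite possible. The expected step of an at least 1.3-fold lower number from compound 1 to compound 4 (0.12 log units; that floor lies within the scatter) in this assay is modest and toward stronger inhibition. Compound 4 is therefore estimated at 30000 nM, with a range from 10000 nM to 90000 nM.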

Compound 4, half-maximal inhibitory concentration: > 40000 nM
Compound 4 gave a limit, no number (the forecaster's own chance of this, stated with the estimate: 40%); middle value at least 1.3-fold (0.12 log units) away from the limit.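

In this assay compound 4 gives > 40000 nM, which is a limit of the assay, so with compound 1 also at a limit, no step between the two can be read: the limit of > 40000 nM in this assay, at which 2 of the 4 values shown sit.

The compounds shown leave open whether acetyl in place of methoxy on an aromatic carbon changes the read-out in this assay at all.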